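Cyclohexyl for tert-butyl in a cytotoxicity test

This account rests on a few compounds, and the source may have more. Where it says the series, first, only, none or still open, it means among the compounds named here.

In an ADME assay on J774.A1 cells (Mus musculus) for cytotoxicity, read by MTT assay, with a stated time of 72 h (on this read-out lower numbers stand for higher toxicity in this test and higher numbers for lower toxicity in this test), the result for compound 1 `CC(C)c1ccc(C(Nc2ccc(C3(C)NC(=O)c4ccccc4N3)cc2)c2nnnn2C2CCCCC2)cc1` is a limit and not a number: > 400000 nM. Among the compounds with values here, compound 2 `CC1(c2ccc(NC(c3ccc(Br)cc3)c3nnnn3C(C)(C)C)cc2)NC(=O)c2ccccc2N1` gives 400000 nM, the only true number so far. Compound 3 `CC1(c2ccc(NC(c3ccc(Br)cc3)c3nnnn3C3CCCCC3)cc2)NC(=O)c2ccccc2N1` departs from compound 2 at one place, with cyclohexyl in place of tert-butyl on an aromatic nitrogen. Within the data shown here, no step between measured compounds exists to guide the estimate, but compound 1 also carries cyclohexyl and sits at the limit of > 400000 nM. The expected change is a 1.1-fold lower number from compound 2 to compound 3 (0.06 log units; within the scatter), which stays within the usual scatter. For compound 3 the estimated value is 350000 nM, with an expected range of 150000 nM to 600000 nM.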

Compound 3, half-maximal cytotoxic concentration: > 400000 nM
Compound 3 was reported as a limit; the forecaster's own chance of this, stated with the estimate: 45%; at least 1.1-fold (0.05 log units) between middle value and limit.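

In this assay, cyclohexyl in place of tert-butyl on an aromatic nitrogen gives a number no lower from compound 2 to compound 3 (the limit leaves the size open). Within the data shown here, this is the first one-place comparison at this position, and it shows no drop in the number when the ring replaces tert-butyl. The size of that step cannot be read, nor can the step between compound 1 and compound 3, because the values crowd at one limit: the limit of > 400000 nM in this assay, at which 2 of the 3 values shown sit.

What the compounds shown leave open is how a longer chain, or a chain carrying an amine or a carboxylic acid, would read on this aromatic nitrogen.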